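The source may hold more compounds than are shown below. What is called first, only, known or untested is meant among the compounds shown, and "the series" means these compounds.

Among the measured compounds shown here, in an ADME assay for permeability, using PAMPA, at pH 7.4 (a higher number here means that the compound crosses the layer faster, a lower number that the compound crosses the layer more slowly), compound 3 (`CCCCC#Cc1c(C)[nH]c2ccc(OC)cc2c1=O`) gives 2440 10^-6 cm/s, the highest of the three numbers measured so far. Compound 1 (`Cc1[nH]c2ccccc2c(=O)c1Cc1ccccc1`) gives 102 10^-6 cm/s and compound 2 (`COc1ccc2[nH]c(C)c(Br)c(=O)c2c1`) gives 16.7 10^-6 cm/s, and both lie lower than compound 3 by more than the scatter.

The next compound, compound 4 (`COc1ccc2[nH]c(C)c(Cc3ccccc3)c(=O)c2c1`), keeps the core of compound 3 but carries benzyl in place of hex-1-yn-1-yl on an aromatic carbon.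

For the measured compounds named here, only one measured step bears directly on this place. It is a 150-fold higher number from compound 2 to compound 3 (2.16 log units; beyond the scatter), a large rise seen when hex-1-yn-1-yl took the place of bromo. Going by the values given here, removing hex-1-yn-1-yl from this place may therefore give up much of that rise, although no measured step shows benzyl entering. The closest guide is compound 1, which also carries benzyl and gives 102 10^-6 cm/s. It is not an exact match for compound 4, so some uncertainty remains.

A large fall in this assay is therefore expected, well beyond the scatter, and the estimated step is a 16-fold lower number from compound 3 to compound 4 (1.21 log units; beyond the scatter). For compound 4 the estimate is 150 10^-6 cm/s, with an expected range from 40 10^-6 cm/s to 550 10^-6 cm/s.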

Compound 4, apparent permeability: 188 10^-6 cm/s
Compound 4: middle estimate off by 1.3-fold (0.10 log units), on the low side, within the range that was stated.
By their numbers in this assay, from the lowest: compound 2; then compounds 1 and 4 (each within the scatter of the next); then compound 3.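

Three groups can now be compared at this place on the aromatic carbon of the shared core in this assay, and they fall into three separate levels. Benzyl gives up most of what hex-1-yn-1-yl carries (a 13-fold lower number from compound 3 to compound 4 (1.11 log units; beyond the scatter)) but still stands well clear of bromo (an 11-fold higher number from compound 2 to compound 4 (1.05 log units; beyond the scatter)), so the high number of compound 3 is not reached by a carbon group of similar size, even though benzyl has only one more heavy atom and also brings no hydrogen-bond donor or acceptor. With benzyl at this place, methoxy in place of hydrogen on an aromatic carbon leaves the two compounds within the scatter of each other (a 1.8-fold higher number from compound 1 to compound 4 (0.27 log units; within the scatter)), so the methoxy group shows no readable effect in this pair.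

The compounds shown do not separate the triple bond from the length of the chain, and they leave open what a saturated hexyl chain, a shorter alkyne or an amine at this place would give. Nothing measured here accounts for the order of bromo, benzyl and hex-1-yn-1-yl.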